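Swapping methoxy for chloro on a weak growth inhibitor

This account rests on a few compounds, and the source may have more. Where it says the series, first, only, none or still open, it means among the compounds named here.

The measured compounds and their values:

Compound 1, `Nc1ccccc1NC(=O)CCCNCC(=O)Nc1ccc(Cl)cc1`: 45000 nM
Compound 2, `COc1ccc(NC(=O)CNc2ccc(C(=O)Nc3ccccc3N)cc2)cc1`: 38000 nM
Compound 3, `COc1ccc(NC(=O)CNCCCC(=O)Nc2ccccc2N)cc1`: 44000 nM

In a functional assay on HCT-116 cells (Homo sapiens) for inhibition, read by MTT assay, with a stated time of 2 days (a lower number here means a stronger inhibitor of growth, a higher number a weaker inhibitor of growth), compound 3 gives 44000 nM, and compound 1 gives 45000 nM. These two differ by chloro in place of methoxy on an aromatic carbon, and the step of a 1.0-fold higher number from compound 3 to compound 1 (0.01 log units; within the scatter) shows that this exchange left the number essentially where it was. Compound 2 gives 38000 nM in this assay; the difference between the core of compound 2 and the core of compound 3 is not broken down here. The three values all lie within the usual scatter of one another, so none can be called stronger or weaker than the rest.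

Compound 4, `Nc1ccccc1NC(=O)c1ccc(NCC(=O)Nc2ccc(Cl)cc2)cc1`, is not yet measured. It differs from compound 2 by chloro in place of methoxy on an aromatic carbon, the same change as that from compound 3 to compound 1. Because the step of a 1.0-fold higher number from compound 3 to compound 1 (0.01 log units; within the scatter) was within the scatter, the step of a 1.1-fold higher number from compound 2 to compound 4 (0.02 log units; within the scatter) is expected to be of similar size in this assay. Compound 4 is therefore estimated at 40000 nM, within a range from 18000 nM to 90000 nM.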

Compound 4, concentration for total growth inhibition: 62500 nM
Compound 4: middle estimate off by 1.6-fold (0.19 log units), on the low side; the measured number falls inside the stated range.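

The same exchange of methoxy for chloro on a second core gives, in this assay, a 1.6-fold higher number from compound 2 to compound 4 (0.22 log units; within the scatter), so on this core too the step cannot be told apart from the spread of repeated measurements. Set side by side, the two cores give no sign of behaving differently toward this change: the same change on two cores in this assay, a 1.0-fold higher number (0.01 log units; within the scatter) from compound 3 to compound 1 and a 1.6-fold higher number (0.22 log units; within the scatter) from compound 2 to compound 4, 1.6-fold (0.21 log units) apart, within the scatter of two such steps This shows only that the exchange produces no readable step on either core; with no real effect to follow, it does not show that a step of real size would carry from one core to the other, and it says nothing about cores beyond these two.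

The compounds shown carry only methoxy or chloro on that aromatic carbon, so it remains open whether a group such as an amine, a carboxylic acid or trifluoromethyl there would give a step beyond the scatter. Also open, going by these compounds, is how a longer chain in the core would read in this assay.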